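Adding a methyl on the amine nitrogen of compound 3

The source may report more compounds than this note shows. Statements on the series, on what has been measured and on what is new or still open speak of the compounds shown alone.

Compound 1 `CNCC1CCCc2cc(S(=O)(=O)c3ccccc3)ccc21` and compound 2 `CN(C)CC1CCCc2cc(S(=O)(=O)c3ccccc3)ccc21` share one core and differ in a single place, (methyl in place of hydrogen on an amine nitrogen). In an assay on isolated protein for displacement of a labelled ligand from 5-hydroxytryptamine receptor 6 (Homo sapiens) (a higher number here means a weaker inhibitor, a lower number a stronger inhibitor), compound 1 gives 0.316 nM, and compound 2 gives 0.0631 nM; this amounts to a 5.0-fold lower number from compound 1 to compound 2 (0.70 log units; beyond the scatter). Compound 3 `NC(=O)CNC[C@@H]1CCCc2cc(S(=O)(=O)c3cccc(F)c3)ccc21` is built on a different core, and the difference between the two cores is not broken down here. In this assay compound 3 gives 0.1 nM, which lies within the scatter of the number for compound 2 and beyond the scatter from the number for compound 1.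

Compound 4 `CN(CC(N)=O)C[C@@H]1CCCc2cc(S(=O)(=O)c3cccc(F)c3)ccc21` is made from compound 3 by the same change, (methyl in place of hydrogen on an amine nitrogen), and the surroundings of the changed nitrogen read the same in both pairs. For the measured compounds named here, the step from compound 3 to compound 4 is expected to be a 2.9-fold lower number from compound 3 to compound 4 (0.46 log units; beyond the scatter), somewhat smaller than the single earlier example, because a 5.0-fold lower number from compound 1 to compound 2 (0.70 log units; beyond the scatter) was seen on only one core and compound 3 already starts from a low number. Compound 4 is therefore estimated at 0.035 nM, with a likely range from 0.012 nM to 0.1 nM.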

Compound 4, inhibition constant: 1.26 nM
Compound 4: the middle estimate sits 36-fold (1.56 log units) below what was measured; the whole stated range lies below it.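

In this assay, methyl in place of hydrogen on an amine nitrogen gives a 13-fold higher number from compound 3 to compound 4 (1.10 log units; beyond the scatter), so the same change does not carry the same result from one core to the other in this series: the same change on two cores in this assay, a 5.0-fold lower number (0.70 log units; beyond the scatter) from compound 1 to compound 2 and a 13-fold higher number (1.10 log units; beyond the scatter) from compound 3 to compound 4, 63-fold (1.80 log units) apart, beyond the scatter of two such steps. The result on the core of compound 1 therefore cannot be used as a guide to the size or direction of the step on the core of compound 3. For the compounds shown here, with only two pairs, this does not show which structural difference between them decides the outcome, nor does it show a general rule for the change on other cores.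

The compounds shown leave open whether the reversal goes with the carbamoylmethyl group on the nitrogen, with the fluorine on the core of compound 3, or with both. Also open, as far as these compounds go, is how the nitrogen of compound 3 would respond to an ethyl group in place of the methyl, or to a carboxylic acid in place of the terminal amide.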